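The source may hold more compounds than are shown below. What is called first, only, known or untested is meant among the compounds shown, and "the series" means these compounds.

Measured compounds:
Compound 1, `CC(=O)Oc1ccc(/C=C/S(=O)(=O)CCc2ccc(NC(=O)c3ccc(C)cc3)cc2)cc1OC(C)=O`, gives 177000 nM in an ADME assay on TZM cells (Homo sapiens) for cytotoxicity, read by CCK-8 assay, with a stated time of 2 days; a lower number here means that less compound is tolerated, a higher number that more compound is tolerated.
Compound 2, `O=C(Nc1ccc(CCS(=O)(=O)/C=C/c2ccc(O)c(O)c2)cc1)c1ccccc1`, gives 238000 nM in this assay.

Compound 2 has the higher of the two numbers, but its nearest neighbour, compound 1, differs by only a small amount that lies within the usual scatter of such measurements, so the two compounds cannot be told apart on this evidence.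

Compound 3, `O=C(Nc1ccc(CCS(=O)(=O)/C=C/c2ccc(O)c(O)c2)cc1)c1ccc(F)cc1`, has not yet been measured. It differs from compound 2 in one place: fluoro in place of hydrogen on an aromatic carbon. The fluoro group enters on the phenyl of the benzamido part, para to a large group.

No comparison of two measured compounds is available that isolates this change. A swap of hydrogen for fluoro on an aromatic carbon is small, and for compound 3 the step from compound 2 is expected to stay within the scatter, as a 1.1-fold lower number from compound 2 to compound 3 (0.03 log units; within the scatter). Compound 3 is therefore estimated at 220000 nM, within a range from 110000 nM to 440000 nM.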

Compound 3, half-maximal cytotoxic concentration: > 1000000 nM
Compound 3 gave a limit, no number; the forecaster's own chance of this, stated with the estimate: 15%; middle value at least 4.5-fold (0.65 log units) away from the limit.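

In this assay compound 3 gives > 1000000 nM, which is a limit of the assay and not a number. Fluoro in place of hydrogen on the phenyl of the benzamido part, para to a large group, gives an at least 4.2-fold higher number from compound 2 to compound 3 (0.62 log units; beyond the scatter), so this position, on which the earlier compounds gave no single-change comparison, proves sensitive to a swap of just one atom. Going by these compounds, the full size of the step stays unknown, as the reading ends at a limit: the limit of > 1000000 nM in this assay, at which 1 of the 3 values shown sits.

On these data alone, whether another group at this place, such as chloro, methoxy or an amine, would bring a similar step remains open. Also open, as far as these compounds go, is whether fluoro would have the same effect at other places on this phenyl.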